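The compounds below may be only part of what the source reports. "The series", "measured", "known", "first", "only" and "open" are said of these compounds alone.

Compound 1 `CN1CCN(c2ccc(S(=O)(=O)Oc3cccc(Cl)c3)cc2)C1=O` serves as the reference point of this small set. Compound 2 `CN1CCN(c2ccc(S(=O)(=O)Oc3cccc([N+](=O)[O-])c3)cc2)C1=O` differs from it by nitro in place of chloro on an aromatic carbon, and compound 3 `CCCN1CCN(c2ccc(S(=O)(=O)Oc3cccc(Cl)c3)cc2)C1=O` differs from it by ethyl in place of hydrogen on a saturated chain carbon bound to an amide-type nitrogen in a ring, which is also how the core of compound 3 differs from the core of compound 1. Compound 4 `CCCN1CCN(c2ccc(S(=O)(=O)Oc3cccc([N+](=O)[O-])c3)cc2)C1=O` combines both changes in a single molecule and has not yet been measured.

In a functional assay on M21 cells (Homo sapiens) for antiproliferative activity, read by sulforhodamine B assay, with a stated time of 48 h (a lower number here means a stronger inhibitor, a higher number a weaker inhibitor), compound 1 gives 1600 nM. In this assay compound 2 gives 23000 nM, a step of a 14-fold higher number from compound 1 to compound 2 (1.16 log units; beyond the scatter). In this assay compound 3 gives 8600 nM, a step of a 5.4-fold higher number from compound 1 to compound 3 (0.73 log units; beyond the scatter), so compound 3 stands between compound 1 and compound 2, and its distance from each of them exceeds the usual scatter.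

Compound 4 differs from compound 3 by nitro in place of chloro on an aromatic carbon, the same change that leads from compound 1 to compound 2 and at the same place. For the measured compounds named here, only that one earlier instance exists, and nothing in these data shows whether the change behaves alike on the core of compound 3. The simplest expectation carries the earlier step over unchanged. Going by the values given here, compound 4 is therefore expected to show a step of a 10-fold higher number from compound 3 to compound 4 (1.02 log units; beyond the scatter) in this assay, because a 14-fold higher number from compound 1 to compound 2 (1.16 log units; beyond the scatter) is the only measured precedent. Compound 4 is estimated at 90000 nM in this assay, with a likely range from 25000 nM to 250000 nM, and a number that weak may be returned only as a limit of the assay.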

Compound 4, half-maximal inhibitory concentration: 38000 nM
Compound 4: the middle estimate sits 2.4-fold (0.37 log units) above what was measured; low and high end bracket the measured number.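

In this assay, nitro in place of chloro still gives a higher number on the core of compound 3, with a 4.4-fold higher number from compound 3 to compound 4 (0.65 log units; beyond the scatter), but the step does not carry over from the core of compound 1 at its earlier size: the same change on two cores in this assay, a 14-fold higher number (1.16 log units; beyond the scatter) from compound 1 to compound 2 and a 4.4-fold higher number (0.65 log units; beyond the scatter) from compound 3 to compound 4, 3.3-fold (0.51 log units) apart, beyond the scatter of two such steps

The same four compounds can be read through the other change, ethyl in place of hydrogen, which stays within the scatter when nitro is present, with a 1.7-fold higher number from compound 2 to compound 4 (0.22 log units; within the scatter), so this step does not carry over from the chloro compounds to the nitro compounds either: the same change on two cores in this assay, a 5.4-fold higher number (0.73 log units; beyond the scatter) from compound 1 to compound 3 and a 1.7-fold higher number (0.22 log units; within the scatter) from compound 2 to compound 4, 3.3-fold (0.51 log units) apart, beyond the scatter of two such steps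

In these four compounds, the two changes therefore do not simply add, and the size of each step differs with the group at the other place, although the nitro change gives a higher number on both cores; this single set of four compounds does not show why the steps differ, nor whether the same holds for other groups.

The compounds shown leave open whether a nitrile or a methoxy group in place of chloro would show the same difference between the two cores. They also leave open how a longer chain on the amide-type nitrogen in the ring would behave with chloro or with nitro.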